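The compounds below may be only part of what the source reports. "The series", "measured", "known", "first", "only" and "open" are said of these compounds alone.

Compound 1 `O=C(NCc1ccc(CNS(=O)(=O)c2ccc3c(c2)CCO3)cc1)c1cccc2c1COC2` belongs to a set of three amides tested in an assay on cells for inhibition of C-X-C chemokine receptor type 4 (Homo sapiens), with a stated time of 22 h, tested at 100 nM; a higher number here means more inhibition at the concentration tested (going by the name of the read-out), a lower number less inhibition. In this assay compound 1 gives 40%, and compound 3 `O=C(NCc1ccc(CNS(=O)(=O)c2ccccc2F)cc1)c1cc2ccccn2n1` gives 40%; these two stand level at the digits shown, within the scatter, and together they are the lowest of the three numbers. Compound 2 `O=C(NCc1ccc(CNS(=O)(=O)c2ccc(F)cc2F)cc1)c1cncnc1` gives 74% in this assay, a number clearly beyond the scatter above compound 1. Compound 4 `O=C(NCc1ccc(CNS(=O)(=O)c2ccc3c(c2)CCO3)cc1)c1scc2c1OCCO2` has not been measured in this assay. It differs from compound 1 only on the carbonyl carbon, where (a group of 9 heavy atoms (6 carbon, 2 oxygen, 1 sulfur; one five-membered aromatic ring with 1 hetero atom, one six-membered non-aromatic ring with 2 hetero atoms) in place of a group of 9 heavy atoms (8 carbon, 1 oxygen; one five-membered non-aromatic ring with 1 hetero atom, one six-membered aromatic ring of carbon only), on a carbonyl carbon). No comparable single-point change among the measured compounds exists, so the step from compound 1 to compound 4 is expected to be small, likely none beyond the scatter, as a number 5 percentage points higher from compound 1 to compound 4 (within the scatter). Compound 4 is therefore estimated at 45%, between 20% and 70%.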

Compound 4, a percentage reported as inhibition, at one concentration (the size of the read-out at that concentration, not a potency): 68%
For compound 4 the middle estimate is 23 percentage points below the measured one; the measured number falls inside the stated range.
By their numbers in this assay, from the lowest: compounds 1 and 3 (each within the scatter of the next); then compounds 4 and 2 (each within the scatter of the next).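

In this assay, the group on the carbonyl carbon turns out to matter, with the rest of the molecule unchanged: the swap gives a number 28 percentage points higher from compound 1 to compound 4 (beyond the scatter). The two groups have the same count of 9 heavy atoms, so the step appears without any change in that count, while the entering group has 3 hydrogen-bond acceptors in place of 1. No evidence on the reason for this step is at hand. Which part of the entering group carries the step stays open, as does how a plain phenyl or a morpholine group would read at this carbonyl carbon.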